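From dimethylamino to dimethoxy: the step to compound 4

A few compounds are considered here, and "the series" means these few. Any claim that something is new, unique, unknown or untested is made for them only; others in the source may bear on it.

Compound 1 `COc1ccc(-c2ccc(-c3ccc(-c4nc5ccccc5[nH]4)cc3)cc2)cc1OC` gives 21600 nM
Compound 2 `COc1ccc(-c2ccc(-c3ccc(-c4nc5c(O)cccc5[nH]4)cc3)cc2)cc1` gives 8640 nM
Compound 3 `CN(C)c1ccc(-c2ccc(-c3ccc(-c4nc5c(O)cccc5[nH]4)cc3)cc2)cc1` gives 3010 nM

In a functional assay on A2780 cells (Homo sapiens) for inhibition, read by sulforhodamine B assay (a lower number here means a stronger inhibitor of growth, a higher number a weaker inhibitor of growth), compound 3 gives 3010 nM and so holds the lowest of the three numbers measured. Compound 4 `COc1ccc(-c2ccc(-c3ccc(-c4nc5c(O)cccc5[nH]4)cc3)cc2)cc1OC` keeps the core of compound 3, and the change is 3,4-dimethoxyphenyl in place of 4-(dimethylamino)phenyl on an aromatic carbon with 3,4-dimethoxyphenyl in place of 4-(dimethylamino)phenyl on an aromatic carbon. The closest evidence is a 2.9-fold lower number from compound 2 to compound 3 (0.46 log units; beyond the scatter) where dimethylamino took the place of methoxy. Compound 4 has no dimethylamino and carries methoxy groups instead, so a step of about that size toward a higher number is expected. Among the measured compounds shown here, compound 1 also carries 3,4-dimethoxyphenyl and reads 21600 nM but its core lacks the hydroxy group, and no measured pair isolates that difference. For the measured compounds named here, it suggests only that the number could run higher. The estimated step is a 2.5-fold higher number from compound 3 to compound 4 (0.40 log units; beyond the scatter) in this assay for this change. For compound 4 the estimate is 7500 nM with 3000 nM to 20000 nM as the expected range.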

Compound 4, concentration for 50% growth inhibition: 2710 nM
The estimate for compound 4 lay 2.8-fold (0.44 log units) above the measured number; the whole stated range lies above it.
By their numbers in this assay, from the lowest: compounds 4 and 3 (each within the scatter of the next); then compound 2; then compound 1.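

In this assay, the exchange of 4-(dimethylamino)phenyl for 3,4-dimethoxyphenyl gives a 1.1-fold lower number from compound 3 to compound 4 (0.05 log units; within the scatter), so at this position dimethylamino is not required for a number of this size, and the two groups cannot be told apart here. Among the compounds shown here, two further pairs each isolate one change: an added methoxy on the outer aromatic ring gives a 3.2-fold lower number from compound 2 to compound 4 (0.50 log units; beyond the scatter), and a hydroxy group on the shared core gives an 8.0-fold lower number from compound 1 to compound 4 (0.90 log units; beyond the scatter), the first direct reading of that group's contribution. No measurement shown accounts for any of these steps.

The compounds shown leave open whether an ethoxy group or a morpholine ring in place of these substituents would give a lower number. They also leave open whether an amine or a carboxylic acid could stand in for the hydroxy group on the core.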